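Succinimide-piperazine amides in the electroshock test: chain shortening

The source may report more compounds than this note shows. Statements on the series, on what has been measured and on what is new or still open speak of the compounds shown alone.

Compound 1 `COc1cccc(N2CCN(C(=O)C(C)N3C(=O)CCC3=O)CC2)c1` and compound 2 `CCC(C(=O)N1CCN(c2cccc(C)c2)CC1)N1C(=O)CCC1=O` share a core in which an arylpiperazine amide carries a succinimide on the chain. In a functional assay on the whole organism (strain Swiss) with Mus musculus as the target, in the maximal electroshock model, with a stated time of 0.5 h, at a dose of 100 mg/kg by the intraperitoneal route (a lower number here means a weaker effect, a higher number a stronger effect of the compound at the dose given), compound 1 gives 0%. In this assay compound 2 gives 0%, level with compound 1 at the digits shown, and no step between the two is computed here. Compound 3 `Cc1cccc(N2CCN(C(=O)C(C)N3C(=O)CCC3=O)CC2)c1` is not yet measured in this assay. Its difference from compound 2: hydrogen in place of methyl on a saturated chain carbon, two bonds along the chain from an amide-type nitrogen in a ring and a carbonyl carbon. Within the data shown here, both measured compounds show no effect, so there is no measured step of any size to lean on; the expected step of no change at the digits printed from compound 2 to compound 3 (within the scatter) is none beyond the scatter, with a small upward allowance. Compound 3 is therefore estimated at 0% in this assay, within a range from 0% to 20%, because compound 2 gave 0%.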

Compound 3, a percentage reported as activity, at one dose (the size of the read-out at that dose, not a potency): 0%
Compound 3: middle estimate and measured number agree at the digits printed; the range from low to high includes it.
By their numbers in this assay, from the lowest: compounds 1, 2 and 3 (each within the scatter of the next).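

In this assay, the change from ethyl to methyl on the saturated chain carbon gives no change at the digits printed from compound 2 to compound 3 (within the scatter), so neither group at this place, two bonds along the chain from an amide-type nitrogen in a ring and a carbonyl carbon, separates the two compounds. The aromatic carbon can now be read on its own as well: methyl in place of methoxy gives no change at the digits printed from compound 1 to compound 3 (within the scatter), a single-place comparison that compounds 1 and 2 alone did not offer. Nothing available explains these readings.

With all three compounds at one reading, neither step shows whether either place can affect the read-out in this assay. Still open, going by these compounds, are a longer chain, such as propyl, on the saturated chain carbon and a chlorine or trifluoromethyl group on the aromatic carbon.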